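Changing 4-methylphenyl to 4-bromophenyl in compound 3

A few compounds are considered here, and "the series" means these few. Any claim that something is new, unique, unknown or untested is made for them only; others in the source may bear on it.

Of the compounds shown here, two have so far been measured in a functional assay on HeLa cells (Homo sapiens) for inhibition, read by MTT assay, with a stated time of 48 h; a higher number here means a weaker inhibitor, a lower number a stronger inhibitor. Compound 1 `Cc1c(NC(=O)NCCN2C(=O)S/C(=C\c3ccc([N+](=O)[O-])cc3)C2=O)c(=O)n(-c2ccccc2)n1C` gives 37700 nM, and compound 2 `Cc1ccc(/C=C2\SC(=O)N(CC(=O)Nc3c(C)n(C)n(-c4ccccc4)c3=O)C2=O)cc1` gives 53100 nM, so these two values lie within the scatter of each other. Going by the values given here, the two compounds differ in more than one place, and no measured pair isolates a single change. Compound 3 `Cc1c(NC(=O)CN2C(=O)S/C(=C\c3ccc(Br)cc3)C2=O)c(=O)n(-c2ccccc2)n1C` has not yet been measured in this assay. It departs from compound 2 in one place: bromo in place of methyl on an aromatic carbon, so that 4-methylphenyl becomes 4-bromophenyl. Among the compounds with values here, with no measured step for this swap, the expectation starts from compound 2 at 53100 nM, and no shift beyond the scatter is expected in either direction. The expected size is a 1.2-fold lower number from compound 2 to compound 3 (0.07 log units; within the scatter). Compound 3 is expected at 45000 nM, with an estimated range from 18000 nM to 100000 nM.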

Compound 3, half-maximal inhibitory concentration: 9410 nM
Compound 3: middle estimate off by 4.8-fold (0.68 log units), on the high side, outside the stated range (below it).
By their numbers in this assay, from the lowest: compound 3; then compounds 1 and 2 (each within the scatter of the next).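

In this assay, the change from 4-methylphenyl to 4-bromophenyl gives a 5.6-fold lower number from compound 2 to compound 3 (0.75 log units; beyond the scatter) and is the only single-place step available among these compounds. It shows that this place on the aromatic ring, para to a large group, is not indifferent to its substituent: exchanging one heavy atom for another, with no hydrogen-bond donor, acceptor or net charge on either side, moves the number beyond the scatter. No measured property of these compounds accounts for the shift.

As far as these compounds go, whether chloro, methoxy or an amine at this place would also lower the number remains open. So does whether bromo would produce a similar step on the chain carried by compound 1, whose different chain and substituent leave the two effects unseparated.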